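A few compounds are considered here, and "the series" means these few. Any claim that something is new, unique, unknown or untested is made for them only; others in the source may bear on it.

Measured in a functional assay on HL-60 cells (Homo sapiens) for cytotoxicity, read by WST assay, with a stated time of 48 h; on this read-out higher numbers stand for an effect only at larger amounts of compound and lower numbers for an effect already at smaller amounts:

- Compound 1 `O=C1OC[C@H](Cc2ccccc2)[C@H]1Cc1ccc(O)cc1`: 88000 nM
- Compound 2 `COc1cc(C[C@H]2C(=O)OC[C@@H]2Cc2ccccc2)cc(OC)c1OC`: > 100000 nM (a limit of the assay, not a number)
- Compound 3 `Oc1cccc(C[C@H]2COC[C@@H]2Cc2ccc(Cl)c(Cl)c2)c1`: 31000 nM

Compound 3 , at 31000 nM, holds the lower of the two actual numbers. Compound 1 , at 88000 nM, lies higher, by more than the usual scatter. Compound 2 gives only a limit and cannot be ranked exactly.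

Compound 4 `Fc1ccc(C[C@H]2COC[C@@H]2Cc2ccc(Cl)c(Cl)c2)cc1` has not yet been measured. Relative to compound 3 , it shows (4-fluorophenyl in place of 3-hydroxyphenyl on a saturated chain carbon bound to a saturated ring carbon), with 4-fluorophenyl in place of 3-hydroxyphenyl on a saturated chain carbon bound to a saturated ring carbon.

Among the compounds with values here, no measured pair differs in one place, so the value of compound 3 , 31000 nM, is the only direct anchor. In this assay, on these data alone, no change beyond the scatter is expected, and the direction remains open. The estimated step, a 1.1-fold higher number from compound 3 to compound 4 (0.05 log units; within the scatter), is expected to stay within the scatter. For compound 4 , the expected value is 35000 nM, with an estimated range of 13000 nM to 95000 nM.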

Compound 4, half-maximal effective concentration: 43000 nM
Estimate against measurement, compound 4: 1.2-fold (0.09 log units) below; measured number inside the range.
By their numbers in this assay, from the lowest: compounds 3 and 4 (each within the scatter of the next); then compound 1. At a limit, above all of these: compound 2.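

In this assay, 4-fluorophenyl in place of 3-hydroxyphenyl on a saturated chain carbon bound to a saturated ring carbon gives a 1.4-fold higher number from compound 3 to compound 4 (0.14 log units; within the scatter). Within the data shown here, this is the first pair that differs in one place, and so the first direct reading of a change at this position. 3-hydroxyphenyl carries a hydrogen-bond donor and acceptor and 4-fluorophenyl carries neither, yet the two compounds stay within the scatter of each other, so in this pair those counted features are not needed to hold the number at this level.

On these data alone, whether an amine or a carboxylic acid at the same place would move the number beyond the scatter remains open. Compound 2 remains unranked, holding only a limit of the assay: the limit of > 100000 nM in this assay, at which 1 of the 4 values shown sits.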